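The source may hold more compounds than are shown below. What is called first, only, known or untested is meant among the compounds shown, and "the series" means these compounds.

Working notes on the series. Of the compounds shown here, three of the shared core have been measured in a toxicity assay on HeLa cells (Homo sapiens) for cytotoxicity, read by colorimetric assay, with a stated time of 72 h; on this read-out higher numbers stand for lower toxicity in this test and lower numbers for higher toxicity in this test. Compound 1 `CC(=O)c1ccc(N2CCN(c3nc(=O)c4cc(C(F)(F)F)cc([N+](=O)[O-])c4s3)CC2)cc1` reaches only a limit of the test: in this assay compound 1 gives > 105000 nM, a limit and not a number. Compound 2 `COc1cc(OC)cc(N2CCN(c3nc(=O)c4cc(C(F)(F)F)cc([N+](=O)[O-])c4s3)CC2)c1` stands at a limit as well, and in this assay compound 2 gives > 101000 nM. Compound 3 `O=c1nc(N2CCN(Cc3ccncc3)CC2)sc2c([N+](=O)[O-])cc(C(F)(F)F)cc12` likewise sits at a limit, and in this assay compound 3 gives > 111000 nM. The steps among these three are all unreadable: a step that the two limits leave unreadable from compound 1 to compound 2, a step that the two limits leave unreadable from compound 1 to compound 3 and a step that the two limits leave unreadable from compound 2 to compound 3 cannot be sized because of the limit of > 101000 nM in this assay, at which 1 of the 3 values shown sits, the limit of > 105000 nM in this assay, at which 1 of the 3 values shown sits, and the limit of > 111000 nM in this assay, at which 1 of the 3 values shown sits, each mark a limit, not a value. On the numbers shown, compound 3 therefore stands level with the other two, at the ceiling of what this test can report.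

Compound 4 `O=C(CN1CCN(c2nc(=O)c3cc(C(F)(F)F)cc([N+](=O)[O-])c3s2)CC1)Nc1ccccc1` differs from compound 3 by phenylcarbamoyl in place of pyridin-4-yl on a saturated chain carbon bound to an amine nitrogen in a ring. All three measured steps bear on the same position on the ring amine, and none of them produced a readable change in this assay. No step beyond the scatter is therefore expected from compound 3 to compound 4; the estimated step of a number no higher from compound 3 to compound 4 (the limit leaves the size open) is meant as essentially none. Compound 4 is expected to give 110000 nM in this assay, with a range from 50000 nM to 200000 nM, most likely again reported only as a limit.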

Compound 4, half-maximal cytotoxic concentration: > 101000 nM
Compound 4: a limit, no number (the forecaster's own chance of this, stated with the estimate: 85%); the middle value lies beyond the limit too.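

In this assay, going by these compounds alone, compound 4 gives > 101000 nM, a limit and not a number, and no step from compound 1, compound 2 or compound 3 to compound 4 can be read. The compounds shown leave open whether the groups on the ring amine differ at all in this assay, as all four values are limits.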